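The source may hold more compounds than are shown below. What is called first, only, known or untested is meant among the compounds shown, and "the series" means these compounds.

Measured so far:
compound 1 `COc1ccnc(Nc2cc3[nH]c(-c4cccc(C(F)(F)F)c4)nc3cn2)c1` — < 5000 nM
compound 2 `Fc1ccc(-c2nc3cnc(Nc4cc(C(F)(F)F)ccn4)cc3[nH]2)cc1F` — < 5000 nM

In a physicochemical assay for solubility, using the shake flask method, in phosphate buffer, measured as kinetic solubility, with a stated time of 20 h, at pH 6.5 (on this read-out lower numbers stand for lower solubility and higher numbers for higher solubility), compound 1 gives only a limit, < 5000 nM. Compound 2 also sits at a limit, < 5000 nM. For the measured compounds named here, both values stand at the limit of < 5000 nM in this assay, at which 2 of the 2 values shown sit, so no order between compound 1 and compound 2 can be read, and no step between measured compounds is available. Compound 3 `O=C(O)c1ccnc(Nc2cc3[nH]c(-c4cccc(C(F)(F)F)c4)nc3cn2)c1` differs from compound 1 by carboxy in place of methoxy on an aromatic carbon. In this assay an upward step beyond the scatter is expected, an at least 4.0-fold higher number from compound 1 to compound 3 (0.60 log units; beyond the scatter). Compound 3 is accordingly estimated at 20000 nM, within 4000 nM to 100000 nM.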

Compound 3, solubility: < 5000 nM
Compound 3 gave a limit, no number; the forecaster's own chance of this, stated with the estimate: 40%; at least 4.0-fold (0.60 log units) between middle value and limit.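

No step can be read between compound 1 and compound 3 in this assay, since both give only a limit: the limit of < 5000 nM in this assay, at which 3 of the 3 values shown sit.

The compounds shown leave open whether carboxy in place of methoxy changes this read-out at all.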